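The source may hold more compounds than are shown below. What is called first, only, known or untested is meant among the compounds shown, and "the series" means these compounds.

In a functional assay on A549 cells (Homo sapiens) for antiproliferative activity, read by MTT assay, with a stated time of 48 h (on this read-out lower numbers stand for stronger inhibition and higher numbers for weaker inhibition), compound 1 (`Cc1ccc(-c2nn(-c3ccccc3)cc2C(Nc2nc3cc(C)c(C)cc3s2)c2c(O)ccc3ccccc23)cc1`) gives 31200 nM. Compound 2 (`Cc1cccc(-c2nn(-c3ccccc3)cc2C(Nc2nc3ccccc3s2)c2c(O)ccc3ccccc23)c1`) gives 18500 nM, and compound 3 (`O=[N+]([O-])c1ccc(-c2nn(-c3ccccc3)cc2C(Nc2nc3ccccc3s2)c2c(O)ccc3ccccc23)cc1`) gives 41300 nM. Compound 1 lies within the scatter of both.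

Compound 4 (`Cc1ccc(-c2nn(-c3ccccc3)cc2C(Nc2nc3ccccc3s2)c2c(O)ccc3ccccc23)cc1`) is still to be measured in this assay. It differs from compound 1 as follows: 1,3-benzothiazol-2-yl in place of 5,6-dimethyl-1,3-benzothiazol-2-yl on an amine nitrogen. In words, this is 1,3-benzothiazol-2-yl in place of 5,6-dimethyl-1,3-benzothiazol-2-yl on an amine nitrogen.

Among the compounds with values here, no measured pair isolates this change. Within the data shown here, the only measured step, a 2.2-fold higher number from compound 2 to compound 3 (0.35 log units; beyond the scatter), is modest and is a change of 4-nitrophenyl in place of 3-methylphenyl on an aromatic carbon, so it bears only indirectly. Compound 2 and compound 3 already carry 1,3-benzothiazol-2-yl, and neither stands beyond the scatter from compound 1.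

No step beyond the scatter is therefore expected, in either direction, and the estimated change is a 1.2-fold lower number from compound 1 to compound 4 (0.10 log units; within the scatter). Compound 4 is estimated at 25000 nM, with an expected range of 13000 nM to 46000 nM.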

Compound 4, half-maximal inhibitory concentration: 57400 nM
Beside the measured number, compound 4's estimate is 2.3-fold (0.36 log units) below it; measured number above the stated range.
By their numbers in this assay, from the lowest: compounds 2, 1, 3 and 4 (each within the scatter of the next, the first and the last beyond it).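

The pair compound 1 and compound 4 now isolates 1,3-benzothiazol-2-yl in place of 5,6-dimethyl-1,3-benzothiazol-2-yl on the amine nitrogen, and in this assay it reads a 1.8-fold higher number from compound 1 to compound 4 (0.26 log units; within the scatter), so this change is not resolved from the scatter. With 1,3-benzothiazol-2-yl held fixed, the aryl group on the aromatic carbon gives a step beyond the scatter for 4-methylphenyl in place of 3-methylphenyl, a 3.1-fold higher number from compound 2 to compound 4 (0.49 log units; beyond the scatter), whereas methyl in place of nitro gives a 1.4-fold higher number from compound 3 to compound 4 (0.14 log units; within the scatter). Among these three compounds, compound 2 alone stands apart, beyond the scatter from both compound 3 and compound 4.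

From the compounds shown here alone, whether a single methyl, a chlorine or a methoxy on the benzothiazolyl group would give a step beyond the scatter remains open, as does the effect of an amine or a carboxylic acid on the phenyl group. No measurement shown gives a reason for any of these steps.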